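This account rests on a few compounds, and the source may have more. Where it says the series, first, only, none or still open, it means among the compounds named here.

Measured so far:
compound 1, `NS(=O)(=O)c1ccc(NC(=O)CSc2nnc(N3C(=O)CSC3c3ccccc3Cl)s2)cc1`: >= 18800 nM
compound 2, `CS(=O)(=O)c1ccc(NC(=O)CSc2nnc(N3C(=O)CSC3c3ccccc3Cl)s2)cc1`: >= 172000 nM

Compound 2 stands in an ADME assay on MT4 cells (Homo sapiens) for cytotoxicity, read by MTT assay, with a stated time of 5 days (a higher number here means that more compound is tolerated, a lower number that less compound is tolerated), not at a number but at a limit of the assay, >= 172000 nM, the highest reading shown. Among the compounds with values here, the only other value shown, for compound 1, is also a limit, >= 18800 nM. Within the data shown here, the single measured step, from compound 1 to compound 2, a step that the two limits leave unreadable from compound 1 to compound 2, changes methyl in place of amino on a sulfonyl sulfur, and its size cannot be read because one end sits at the limit of >= 18800 nM in this assay, at which 1 of the 2 values shown sits, and the other at the limit of >= 172000 nM in this assay, at which 1 of the 2 values shown sits.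

Compound 3, `CS(=O)(=O)c1ccc(NC(=O)CSc2nnc(N3C(=O)CSC3c3ccc(Cl)cc3)s2)cc1`, differs from compound 2 by 4-chlorophenyl in place of 2-chlorophenyl on a saturated ring carbon. Among the measured compounds shown here, no measured step touches a change of this kind, so nothing in the data points in either direction, and no step beyond the usual scatter is expected in this assay. Since compound 2 itself is read only as a limit, compound 3 is expected to come out as a limit as well, with the estimated step of a number no higher from compound 2 to compound 3 (the limit leaves the size open). The estimate for compound 3 is 172000 nM, in the range 60000 nM to 300000 nM.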

Compound 3, half-maximal cytotoxic concentration: 116000 nM
For compound 3 the middle estimate is 1.5-fold (0.17 log units) above the measured one; the range from low to high includes it.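

In this assay compound 3 gives 116000 nM, the only reading shown so far that is a number and not a limit of the assay, which gives this series its first firm value for how much compound the cells tolerate. Placing 4-chlorophenyl in place of 2-chlorophenyl on this saturated ring carbon gives an at least 1.4-fold lower number from compound 2 to compound 3 (0.17 log units; that floor lies within the scatter), so the data show no change beyond the scatter, though they also do not rule out a larger one. Compound 2 stands at a limit and not at a number, so this step is only a floor and its true size stays unknown: the limit of >= 172000 nM in this assay, at which 1 of the 3 values shown sits.

The step with a limit at each end, between the methyl and amino groups on the sulfonyl sulfur, still cannot be read, and the compounds shown do not tell whether that swap would matter alongside 4-chlorophenyl. They also leave open how this ring carbon would read with an unsubstituted phenyl, a methoxyphenyl or a pyridine ring in place of the chlorophenyl groups.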